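A few compounds are considered here, and "the series" means these few. Any claim that something is new, unique, unknown or untested is made for them only; others in the source may bear on it.

Compound 2 `O=C(Nc1nccs1)c1cccc(Nc2ncc(F)c(Nc3ccc(F)cc3)n2)c1` was tested in a functional assay on A549 cells (Homo sapiens) for antiproliferative activity, read by sulforhodamine B assay, with a stated time of 3 days (on this read-out higher numbers stand for weaker inhibition of growth and lower numbers for stronger inhibition of growth), and for compound 2 only a limit is recorded, > 10000 nM. Its two neighbours carry numbers: compound 1 `O=C(Nc1ccccn1)c1cccc(Nc2ncc(F)c(Nc3ccc(F)cc3)n2)c1` gives 15300 nM, and compound 3 `O=C(Nc1cc(Cl)cc(Cl)c1)c1cccc(Nc2ncc(F)c(Nc3ccc(F)cc3)n2)c1` gives 17500 nM. The step of a 1.1-fold higher number from compound 1 to compound 3 (0.06 log units; within the scatter) is small, while the steps a step that the limit leaves unreadable from compound 1 to compound 2 and a step that the limit leaves unreadable from compound 2 to compound 3 cannot be read because of the limit of > 10000 nM in this assay, at which 1 of the 3 values shown sits. Compound 4 `CN(C)CC(=O)Nc1cccc(Nc2ncc(F)c(Nc3ccc(F)cc3)n2)c1` differs from compound 2 by (((dimethylamino)methyl)carbonyl)amino in place of (1,3-thiazol-2-yl)carbamoyl on an aromatic carbon. Among the compounds with values here, none of the measured steps changes this part of the shared core in the same way, and all three measured compounds sit in the region of weak inhibition of growth, so no shift beyond the scatter is expected. The expected step is a step that the limit leaves unreadable from compound 2 to compound 4. Compound 4 is estimated at 14000 nM, between 5000 nM and 40000 nM.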

Compound 4, concentration for 50% growth inhibition: 1180 nM
Compound 4: the middle estimate sits 12-fold (1.07 log units) above what was measured, outside the stated range (below it).
By their numbers in this assay, from the lowest: compound 4; then compounds 1 and 3 (each within the scatter of the next).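

In this assay this position proves responsive: compound 1 and compound 3 lie within the scatter of each other, yet (((dimethylamino)methyl)carbonyl)amino gives a 13-fold lower number from compound 1 to compound 4 (1.11 log units; beyond the scatter) and a 15-fold lower number from compound 3 to compound 4 (1.17 log units; beyond the scatter). Compound 2 carries only a limit, > 10000 nM. Measured against that limit, the change still gives an at least 8.4-fold lower number from compound 2 to compound 4 (0.92 log units; beyond the scatter).

The change removes the ring, reverses the amide and adds the dimethylamino end all at once, and the compounds shown do not separate these parts. A plain acetylamino group, or a longer chain ending in a morpholine, would help show which part matters.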